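Cyclohexanone bis-benzylidenes: estimating a dichlorophenyl replacement

The source may report more compounds than this note shows. Statements on the series, on what has been measured and on what is new or still open speak of the compounds shown alone.

Measured compounds in a functional assay on HT-1080 cells (Homo sapiens) for cytotoxicity, read by MTT assay, with a stated time of 72 h; on this read-out higher numbers stand for weaker inhibition and lower numbers for stronger inhibition:
- compound 1 `COc1ccccc1/C=C1\CCC/C(=C\c2cccc(OC)c2OC)C1=O` gives 14100 nM
- compound 2 `COc1cccc(/C=C2\CCC/C(=C\c3cc(Cl)cc(Cl)c3)C2=O)c1OC` gives 6100 nM
- compound 3 `COc1ccc(/C=C2\CCC/C(=C\c3ccc(Cl)cc3)C2=O)cc1OC` gives 4800 nM

Compound 3 shows the lowest of the three numbers in this assay. Its nearest neighbour is compound 2, whose number lies within the scatter of that of compound 3, so no order can be read between these two. Compound 1 stands furthest away, with a number beyond the scatter above that of compound 3.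

Compound 4 `COc1ccc(/C=C2\CCC/C(=C\c3cccc(Cl)c3Cl)C2=O)cc1OC` has not yet been measured. It differs from compound 3 in one place: 2,3-dichlorophenyl in place of 4-chlorophenyl on a double-bonded chain carbon bound to a double-bonded ring carbon

For the measured compounds named here, the only measured step that bears on such a change is a 2.3-fold lower number from compound 1 to compound 2 (0.36 log units; beyond the scatter), where a methoxy-bearing phenyl gave way to a dichlorophenyl. The step now at hand moves from one chlorophenyl to another, and compound 2 with its 3,5-dichlorophenyl and compound 3 with its 4-chlorophenyl sit within the scatter of each other, so the expected step of a 1.1-fold lower number from compound 3 to compound 4 (0.03 log units; within the scatter) is small, in either direction, and not expected to rise beyond the scatter. Compound 4 is therefore estimated at 4500 nM in this assay, with a range from 2000 nM to 10000 nM.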

Compound 4, half-maximal inhibitory concentration: 8800 nM
For compound 4 the middle estimate is 2.0-fold (0.29 log units) below the measured one; measured number inside the range.
By their numbers in this assay, from the lowest: compounds 3, 2, 4 and 1 (each within the scatter of the next, the first and the last beyond it).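

In this assay, the change at this place gives a 1.8-fold higher number from compound 3 to compound 4 (0.26 log units; within the scatter), so replacing 4-chlorophenyl with 2,3-dichlorophenyl on a double-bonded chain carbon bound to a double-bonded ring carbon leaves the number within the scatter. The earlier step at such a place, a 2.3-fold lower number from compound 1 to compound 2 (0.36 log units; beyond the scatter), replaced a methoxy-bearing phenyl and lay beyond the scatter, whereas this first exchange of one chlorine-bearing phenyl for another yields no readable difference, and so a dichlorophenyl group does not bring a step beyond the scatter in every setting shown. No measurement is available that could explain the result at this place.

Since 4-chlorophenyl and 2,3-dichlorophenyl differ both in the number of chlorines and in where they stand, this one step cannot separate those two changes, and a 3-chlorophenyl or a 2-chlorophenyl group on the same core would be needed to tell them apart. On these data alone, it also remains open whether a phenyl bearing an amine or a carboxylic acid at this place would give a step beyond the scatter in this assay.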